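Bromo to Methoxy on a Weakly Cytotoxic Thiazole Hydrazone Pair

The source may hold more compounds than are shown below. What is called first, only, known or untested is meant among the compounds shown, and "the series" means these compounds.

Measured compounds:
compound 1 `O=C(CSc1ncccn1)N/N=c1/scc(-c2ccc(Br)cc2)n1-c1ccccc1`, 76.4%
compound 2 `Cc1nnc(SCC(=O)N/N=c2/scc(-c3ccc(F)cc3)n2-c2ccccc2)s1`, 74.3%

In a functional assay on C6 cells (Rattus norvegicus) for cytotoxicity, read by MTT assay, with a stated time of 24 h, tested at 6 ug/mL (on this read-out higher numbers stand for a weaker effect at the one concentration tested and lower numbers for a stronger effect), compound 1 gives 76.4%, the highest of the two numbers, with compound 2 at 74.3% lying within the scatter of it; the two values are therefore indistinguishable. Compound 3 `COc1ccc(-c2cs/c(=N/NC(=O)CSc3ncccn3)n2-c2ccccc2)cc1` has not yet been measured. It differs from compound 1 by methoxy in place of bromo on an aromatic carbon. Among the measured compounds shown here, no step between measured compounds covers this change, so the expected step from compound 1 to compound 3 in this assay, a number 1.6 percentage points higher from compound 1 to compound 3 (within the scatter), is estimated to be small and not beyond the scatter. Compound 3 is expected to give about 78%, within 64% to 92%.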

Compound 3, a percentage reported as activity, at one concentration (the size of the read-out at that concentration, not a potency): 89.6%
Estimate against measurement, compound 3: 11.6 percentage points below; the range from low to high includes it.
By their numbers in this assay, from the lowest: compounds 2 and 1 (each within the scatter of the next); then compound 3.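

In this assay the change from 4-bromophenyl to 4-methoxyphenyl gives a number 13.2 percentage points higher from compound 1 to compound 3 (beyond the scatter) and so a weaker effect at the one concentration tested. Among the compounds shown here, this is the first comparison here of compounds that differ in one place, and it shows that the read-out responds to the group at this position on the aromatic ring. Nothing among the data given explains this step.

As far as these compounds go, whether an amine or a carboxylic acid at this position would weaken or strengthen the effect remains open. So does whether methoxy in place of bromo gives a similar step on other compounds.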